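An Ethyl Group Becomes Propargyl

A few compounds are considered here, and "the series" means these few. Any claim that something is new, unique, unknown or untested is made for them only; others in the source may bear on it.

In a functional assay on HepG2 cells (Homo sapiens) for cytotoxicity, read by sulforhodamine B assay, with a stated time of 48 h (a lower number here means a stronger inhibitor, a higher number a weaker inhibitor), compound 1 `N#Cc1c(-c2ccc(Cl)cc2)cc(-c2ccc(Cl)cc2)[nH]c1=O` is reported as "not active" (no number reported) without a number. Among the compounds with values here, compound 2 `CCn1c(-c2ccc(Cl)cc2)cc(-c2ccc(Cl)cc2)c(C#N)c1=O` gives 22.3 ug/mL as the only number so far, so it cannot yet be ranked against another value. Compound 3 `C#CCn1c(-c2ccc(Cl)cc2)cc(-c2ccc(Cl)cc2)c(C#N)c1=O` differs from compound 2 in one place ethynyl in place of methyl on a saturated chain carbon bound to an aromatic nitrogen with ethynyl in place of methyl on a saturated chain carbon bound to an aromatic nitrogen. Within the data shown here, no measured step shows what this change does, so no step beyond the scatter is expected in this assay in either direction. The estimate means an expected step of a 1.1-fold lower number from compound 2 to compound 3 (0.05 log units; within the scatter) and no more. Compound 3 is estimated at 20 ug/mL with an expected range from 8 ug/mL to 50 ug/mL overall.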

Compound 3, half-maximal inhibitory concentration: 18.3 ug/mL
Beside the measured number, compound 3's estimate is 1.1-fold (0.04 log units) above it; low and high end bracket the measured number.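

In this assay this position now has a measured step, a 1.2-fold lower number from compound 2 to compound 3 (0.09 log units; within the scatter), so ethyl to propargyl separates compound 2 and compound 3 by no more than repeat measurements would. Ethynyl in place of methyl on a saturated chain carbon bound to an aromatic nitrogen therefore leaves the cytotoxicity reading effectively unchanged in this pair. No supporting data are available to explain this result. One step cannot show how far this position tolerates change. A longer chain, an amine or a carboxylic acid at this carbon remains an open case.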